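Pyrazine hydrazones on macrophage cells: toward an ethoxy analogue

The compounds below may be only part of what the source reports. "The series", "measured", "known", "first", "only" and "open" are said of these compounds alone.

Compound 1 `O=C(N/N=C/c1ccc(Cl)cc1)c1cnccn1`: 83%
Compound 2 `O=C(N/N=C/c1ccccc1F)c1cnccn1`: 100%
Compound 3 `O=C(N/N=C/c1cccc(F)c1)c1cnccn1`: 49%

Three hydrazones sharing the core of compound 1 have been tested in an ADME assay on J774 cells (Mus musculus) for cytotoxicity, read by MTT assay, with a stated time of 48 h, tested at 50 ug/mL; on this read-out lower numbers stand for a stronger effect and higher numbers for a weaker effect at the one concentration tested. Compound 2 gives 100% in this assay, and compound 3 gives 49%. Compound 1 gives 83% and stands second highest of the three numbers; its nearest neighbour is compound 2, whose number lies higher by a margin beyond the scatter, while compound 3 lies lowest, also beyond the scatter.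

Compound 4 `CCOc1ccc(/C=N/NC(=O)c2cnccn2)cc1` has not yet been measured in this assay. It differs from compound 1 in one place: ethoxy in place of chloro on an aromatic carbon. Within the data shown here, no measured pair isolates such a change, so the expectation rests on compound 1 alone. The step of a number 2 percentage points higher from compound 1 to compound 4 (within the scatter) is expected to stay within the scatter. Compound 4 is therefore estimated to give 85%, within a range from 60% to 100%.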

Compound 4, a percentage reported as activity, at one concentration (the size of the read-out at that concentration, not a potency): 100%
Compound 4: the middle estimate sits 15 percentage points below what was measured; the measured number falls inside the stated range.
By their numbers in this assay, from the lowest: compound 3; then compound 1; then compounds 2 and 4 (each within the scatter of the next).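

In this assay, among these compounds, the step of a number 17 percentage points higher from compound 1 to compound 4 (beyond the scatter) is the first reading of a single change, with ethoxy in place of chloro on an aromatic carbon, para to a large group. It shows that the read-out responds to the group at this position, modestly but beyond the scatter. No data at hand bear on the reason for this step. From the compounds shown here alone, whether an amine or a longer chain such as butoxy at this position would follow the same direction remains open. So does whether ethoxy would give a similar step elsewhere on the ring.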